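The source may hold more compounds than are shown below. What is called first, only, known or untested is meant among the compounds shown, and "the series" means these compounds.

Measured in a toxicity assay on microsomes from liver (Homo sapiens) for metabolic stability, read by LC-MS, using NADPH, tested at 1 uM; a higher number here means faster removal of the compound, a lower number slower removal:
compound 1 `CCOc1ncc(-c2nc(C(F)(F)F)sc2N2CCN(C(=O)Cn3ccc4cnccc43)[C@H](C)C2)cn1`: 656 mL.min-1.g-1
compound 2 `CCOc1ncc(-c2nc(C(F)(F)F)sc2N2CCN(C(=O)Cn3nc(C)nc3C)[C@H](C)C2)cn1`: < 10 mL.min-1.g-1 (a limit of the assay, not a number)
compound 3 `CCOc1ncc(-c2nc(C(F)(F)F)sc2N2CCN(C(=O)Cn3ccc(C(F)(F)F)n3)[C@H](C)C2)cn1`: 20 mL.min-1.g-1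

Compound 2 carries no number, only a limit: the limit of < 10 mL.min-1.g-1 in this assay, at which 1 of the 3 values shown sits. Two large steps separate the others from compound 1: an at least 65-fold lower number from compound 1 to compound 2 (1.81 log units; beyond the scatter) and a 33-fold lower number from compound 1 to compound 3 (1.52 log units; beyond the scatter). The third comparison gives an at least 2.0-fold higher number from compound 2 to compound 3 (0.30 log units; that floor lies within the scatter).

Compound 4 `Cc1nc(C)n(CC(=O)N2CCN(c3sc(C(F)(F)F)nc3-c3cnc(OC4CCC4)nc3)C[C@H]2C)n1` keeps the rest of compound 2 and differs in one group: cyclobutyl in place of ethyl on an oxygen on an aromatic ring, that is, ethoxy to cyclobutyloxy. All three measured steps change the group on the saturated chain carbon bound to a carbonyl carbon, and none touches the group on the oxygen. They therefore show how far the number can move in this series, not what this change will do. Among the measured compounds shown here, with only this indirect guidance, a modest rise from the limit seems the likeliest outcome, on the smaller scale of an at least 2.0-fold higher number from compound 2 to compound 3 (0.30 log units; that floor lies within the scatter) and not that of an at least 65-fold lower number from compound 1 to compound 2 (1.81 log units; beyond the scatter). The expected step in this assay is an at least 2.0-fold higher number from compound 2 to compound 4 (0.30 log units; that floor lies within the scatter). For compound 4 the estimate is 20 mL.min-1.g-1, with an expected range of 10 mL.min-1.g-1 to 60 mL.min-1.g-1.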

Compound 4, intrinsic clearance in microsomes in the Homo sapiens assay: 51 mL.min-1.g-1
Estimate against measurement, compound 4: 2.6-fold (0.41 log units) below; low and high end bracket the measured number.
By their numbers in the Homo sapiens assay, from the lowest: compound 3; then compound 4; then compound 1. At a limit, below all of these: compound 2.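

This is the first change shown on an oxygen on an aromatic ring, and in the Homo sapiens assay cyclobutyl in place of ethyl gives a rise that the limit does not hide, with an at least 5.1-fold higher number from compound 2 to compound 4 (0.70 log units; beyond the scatter). Compound 2 stands at a limit of the assay, not a number, so this step is only a floor: the limit of < 10 mL.min-1.g-1 in the Homo sapiens assay, at which 1 of the 4 values shown sits. In a physicochemical assay for lipophilicity, at pH 7.4 (on this read-out lower numbers stand for lower lipophilicity and higher numbers for higher lipophilicity), compound 2 gives 2.8 and compound 4 gives 3.6. Over this one pair, faster removal comes together with higher lipophilicity: the measured distribution coefficient of compound 2, 2.8, and of compound 4, 3.6, a number 0.80 log units higher (beyond the scatter).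

The compounds shown leave open whether the step holds when the group on the saturated chain carbon bound to a carbonyl carbon differs, as it does in compound 3. They also leave open how a methyl, an isopropyl or an oxetanyl group on the same oxygen would read in the Homo sapiens assay.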